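The source may hold more compounds than are shown below. What is called first, only, known or untested is meant among the compounds shown, and "the series" means these compounds.

Measured so far:
- compound 1 `c1ccc(C2=NN(C3=NC(c4ccccc4)CS3)C(c3cccc4ccccc34)C2)cc1`; in a functional assay on BGC-823 cells (Homo sapiens) for inhibition, read by CCK-8 assay, with a stated time of 48 h (on this read-out higher numbers stand for weaker inhibition and lower numbers for stronger inhibition), compound 1 gives 14300 nM.
- compound 2 `Cc1ccc(C2=NN(C3=NC(c4ccccc4)CS3)C(c3cccc4ccccc34)C2)cc1C`; in this assay compound 2 gives 8460 nM.
- compound 3 `Cc1ccc(C2=NN(C3=NC(c4ccccc4)CS3)C(c3ccc4ccccc4c3)C2)cc1C`; in this assay compound 3 gives 6570 nM.

All three numbers are high, so all three compounds inhibit only weakly. Among them compound 2 holds the second highest number. Its nearest gap is the step of a 1.3-fold lower number from compound 2 to compound 3 (0.11 log units; within the scatter), and its furthest is the step of a 1.7-fold lower number from compound 1 to compound 2 (0.23 log units; within the scatter); both lie within the scatter, so the three compounds cannot be told apart on these numbers.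

Compound 4 `Brc1ccc(C2=NN(C3=NC(c4ccccc4)CS3)C(c3cccc4ccccc34)C2)cc1` differs from compound 2 in one place: 4-bromophenyl in place of 3,4-dimethylphenyl on a carbon with a double bond to nitrogen. Going by the values given here, only one measured step touches this same position, namely the change from phenyl to 3,4-dimethylphenyl in a 1.7-fold lower number from compound 1 to compound 2 (0.23 log units; within the scatter), and it stayed within the scatter. Among the compounds with values here, no measured compound carries a bromine anywhere, so there is nothing that speaks for a change in either direction. The expectation in this assay is therefore no step beyond the scatter. On that basis compound 4 is estimated at 9000 nM, with a range from 3000 nM to 27000 nM. The step this estimate implies, a 1.1-fold higher number from compound 2 to compound 4 (0.03 log units; within the scatter), is expected to be small.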

Compound 4, half-maximal inhibitory concentration: 17400 nM
Compound 4: the middle estimate sits 1.9-fold (0.29 log units) below what was measured, within the range that was stated.
By their numbers in this assay, from the lowest: compounds 3, 2, 1 and 4 (each within the scatter of the next, the first and the last beyond it).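

Going by these compounds alone, the position on the carbon with a double bond to nitrogen can register a change in this assay: swapping 3,4-dimethylphenyl for 4-bromophenyl gives the first step at this position to pass the scatter, though only modestly (in numbers, a 2.1-fold higher number from compound 2 to compound 4 (0.31 log units; beyond the scatter)). The comparison with the unsubstituted phenyl group puts that step in context, as adding bromo to the phenyl ring of compound 1 stays within the scatter (here, a 1.2-fold higher number from compound 1 to compound 4 (0.09 log units; within the scatter)), so compound 1 cannot be told apart from compound 4 and the only readable difference lies between the dimethyl and bromo compounds, which differ at two ring carbons rather than one. Nothing measured here accounts for that difference.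

The compounds shown leave open whether an amine, a hydroxyl group or a carboxylic acid on this phenyl ring would shift the number well beyond the scatter in either direction, which would show how much this position can really contribute. They also leave open whether 4-bromophenyl would give a similar result when paired with naphthalen-2-yl in place of naphthalen-1-yl on the saturated ring carbon.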